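Swapping Pyridyl for Naphthyl on a Sulfonyl Sulfur

The compounds below may be only part of what the source reports. "The series", "measured", "known", "first", "only" and "open" are said of these compounds alone.

Compound 1 `O=c1cc(N2CCN(CC3CCC(OS(=O)(=O)c4cccnc4)CC3)CC2)sc2c([N+](=O)[O-])cc(C(F)(F)F)cc12` is the starting point. In an ADME assay on Vero cells (Chlorocebus sabaeus) for cytotoxicity, read by MTT assay, with a stated time of 48 h (a lower number here means a stronger inhibitor, a higher number a weaker inhibitor), compound 1 gives > 64 ug/mL, which is a limit of the assay rather than a measured number. Compound 2 `CCCC(=O)OC1CCC(CN2CCN(c3cc(=O)c4cc(C(F)(F)F)cc([N+](=O)[O-])c4s3)CC2)CC1` carries propylcarbonyl in place of (pyridin-3-yl)sulfonyl on an oxygen on a saturated carbon. In this assay compound 2 gives > 64 ug/mL, again a limit. The step that the two limits leave unreadable from compound 1 to compound 2 therefore cannot be sized, and both values sit at the limit of > 64 ug/mL in this assay, at which 2 of the 2 values shown sit. Compound 3 `O=c1cc(N2CCN(CC3CCC(OS(=O)(=O)c4ccc5ccccc5c4)CC3)CC2)sc2c([N+](=O)[O-])cc(C(F)(F)F)cc12` differs from compound 1 by naphthalen-2-yl in place of pyridin-3-yl on a sulfonyl sulfur. Among the measured compounds shown here, no measured step touches the group on the sulfonyl sulfur, so only the two limits guide the expectation. Because both known values rest at the limit of > 64 ug/mL in this assay, at which 2 of the 2 values shown sit, compound 3 is expected to land at the same limit. The expected step that the limit leaves unreadable from compound 1 to compound 3 is none beyond the scatter. Compound 3 is thus estimated at 100 ug/mL, with a range from 40 ug/mL to 300 ug/mL.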

Compound 3, half-maximal inhibitory concentration: > 64 ug/mL
Compound 3 gave a limit, no number; the forecaster's own chance of this, stated with the estimate: 80%; the middle value does not contradict the limit.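

The step from compound 1 to compound 3, naphthalen-2-yl in place of pyridin-3-yl, cannot be sized, because each value is a limit and not a number: the limit of > 64 ug/mL in this assay, at which 3 of the 3 values shown sit.

The compounds shown leave open at what concentration compound 1, compound 2 or compound 3 would begin to harm the cells.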